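Methyl in Place of Cyclobutyl on an Aromatic Nitrogen

The source may report more compounds than this note shows. Statements on the series, on what has been measured and on what is new or still open speak of the compounds shown alone.

Measured so far:
compound 1 `O=C(O)c1cc(-c2cccc(COc3ccc4c(c3)CN(C3CCCC3)C4=O)c2)ccc1O`: 98%
compound 2 `O=C(O)c1cc(-c2cccc(COc3ccc4c(=O)n(C5CCC5)sc4c3)c2)ccc1Cl`: 91%

Both numbers come from an ADME assay on a cell-free system (plasma, Rattus norvegicus) for metabolic stability, read by LC-MS, with a stated time of 1 h, at 37 degrees C, tested at 100 uM; a lower number here means that less of the compound is left, a higher number that more of the compound is left. In this assay compound 1 gives 98%, and compound 2 gives 91%. Compound 2 stands at the lower of the two numbers, but the gap to its nearest neighbour, compound 1, falls within the scatter of the measurement, so the two compounds cannot be told apart on these data. Within the data shown here, no pair that differs in a single place has been measured, so no step of known size is available.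

Compound 3 `Cn1sc2cc(OCc3cccc(-c4ccc(Cl)c(C(=O)O)c4)c3)ccc2c1=O` differs from compound 2 in one place: methyl in place of cyclobutyl on an aromatic nitrogen. Given that compound 2 already gives 91%, and that compound 1 gives 98% with a different substituent on its core, the step from compound 2 to compound 3 in this assay is expected to be small, a number 2 percentage points higher from compound 2 to compound 3 (within the scatter), with no change beyond the scatter in either direction. Compound 3 is therefore estimated at 93%, within a range from 82% to 100%.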

Compound 3, percent of the compound remaining: 100%
Beside the measured number, compound 3's estimate is 7 percentage points below it; the measured number falls inside the stated range.
By their numbers in this assay, from the lowest: compounds 2, 1 and 3 (each within the scatter of the next).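

In this assay, among these compounds, the exchange of cyclobutyl for methyl on the aromatic nitrogen gives a number 9 percentage points higher from compound 2 to compound 3 (within the scatter) and so provides the first step of known size at this position, next to the ring sulfur. On this read-out, the four-membered ring of carbon can therefore give way to a single carbon without a step beyond the scatter, and compound 2 and compound 3 cannot be told apart. Nothing available explains the size of this step or ties it to any property of either group.

Going by these compounds, the two compounds cover only cyclobutyl and methyl on this nitrogen, so a wider reading of the position is not yet possible, and it remains open whether a longer chain ending in an amine, or one ending in a carboxylic acid, would give a step beyond the scatter. On these data alone, it also remains open whether the same exchange of cyclobutyl for methyl would give a step of similar size on a different core.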